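A few compounds are considered here, and "the series" means these few. Any claim that something is new, unique, unknown or untested is made for them only; others in the source may bear on it.

Among the measured compounds shown here, compound 2, with the structure `O=C(O)CCCC[C@@H]1CC[C@@H]2[C@@H](/C=C/[C@@H](O)COc3ccccc3)[C@H](O)C[C@@H]2OC1`, stands at the top of the two numbers measured so far: in a functional assay on CHO cells for agonist activity at prostaglandin E2 receptor EP3 subtype (Homo sapiens), read by fluorescence and calcium flux (a lower number here means that less compound is needed, a higher number that more compound is needed for the effect), compound 2 gives 130 nM, whereas compound 1, drawn as `O=C(O)CCC[C@H]1CC[C@@H]2[C@@H](/C=C/[C@@H](O)COc3ccccc3)[C@H](O)C[C@@H]2OC1`, gives 4 nM in this assay, a gap well beyond the scatter. Compound 3, with the structure `O=C(O)CCCC[C@H]1CC[C@@H]2[C@@H](/C=C/[C@@H](O)COc3ccccc3)[C@H](O)C[C@@H]2OC1`, has not yet been measured. Its relation to compound 2 is the narrowest kind of change: the two compounds have the same atoms and bonds and differ only in configuration as drawn: 1 of 7 stereo elements differ; a stereocentre at a saturated ring carbon is drawn R in compound 2 and S in compound 3. Nothing is lost or gained; only the drawn configuration at that ring carbon is turned around. For the measured compounds named here, no step between measured compounds shows what such an inversion does on this core, so the expectation rests on the spread the two measured values already display. A single stereocentre on a ring that carries the acid chain is the sort of change that can move a number sharply, and the estimate places compound 3 toward the lower end of that spread, with an 11-fold lower number from compound 2 to compound 3 (1.03 log units; beyond the scatter) taken as the expected step. Compound 3 is therefore estimated at 12 nM in this assay, with a plausible range from 2 nM to 80 nM.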

Compound 3, half-maximal effective concentration: 540 nM
Compound 3: the middle estimate sits 45-fold (1.65 log units) below what was measured; measured number above the stated range.
By their numbers in this assay, from the lowest: compound 1; then compound 2; then compound 3.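

In this assay, among the compounds shown here, turning around the drawn configuration at the saturated ring carbon that carries the acid chain gives a 4.2-fold higher number from compound 2 to compound 3 (0.62 log units; beyond the scatter), the first step on this core that isolates this stereocentre. The step can be assigned to that ring carbon alone, since nothing else separates the pair: the fact that compounds 2 and 3 differ only in the configuration as drawn. The change in the chain is much the larger of the two new steps: carboxymethyl in place of carboxy, on a saturated chain carbon three bonds along the chain from a saturated ring carbon, gives a 140-fold higher number from compound 1 to compound 3 (2.13 log units; beyond the scatter), so this assay responds to the chain change far more strongly than to the inversion.

The compounds shown leave open what the same inversion does when the chain ends in carboxy on the shorter chain of compound 1, and whether a still longer chain would take the number higher again. They also leave open whether a methyl ester, an amide or a tetrazole in place of the carboxylic acid would keep the low number of compound 1 or follow the step seen with the carboxymethyl chain.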